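Inverting a saturated ring stereocentre: compound 3 to compound 4

The source may hold more compounds than are shown below. What is called first, only, known or untested is meant among the compounds shown, and "the series" means these compounds.

Compound 3 `COc1cc(N)c(Cl)cc1C(=O)NC1CCN2C[C@H](c3ccccc3)CC2C1` stands at a limit only: in a functional assay on the whole organism for antagonist activity, with Mus musculus as the target (on this read-out lower numbers stand for an effect already at smaller amounts and higher numbers for an effect only at larger amounts of compound), compound 3 gives > 3 mg/kg, which is a limit of the assay and not a number. The two other values shown are limits as well. Compound 1 `COc1cc(N)c(Cl)cc1C(=O)NC1CCN2C[C@H](c3ccccc3)CCC2C1` gives > 1 mg/kg in this assay, again a limit. Compound 2 `COc1cc(N)c(Cl)cc1C(=O)NC1CCN2C[C@@H](c3ccccc3)CCC2C1` gives > 1 mg/kg, also a limit. The step that the two limits leave unreadable from compound 1 to compound 2 therefore carries no readable size; this follows from the limit of > 1 mg/kg in this assay, at which 2 of the 3 values shown sit, together with the fact that one of compounds 1 and 2 is drawn with a defined configuration and the other without, at the place where they differ.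

Compound 4 `COc1cc(N)c(Cl)cc1C(=O)NC1CCN2C[C@@H](c3ccccc3)CC2C1` is not yet measured. It differs from compound 3 by the two compounds have the same atoms and bonds; at least one stereo element is drawn with a configuration in one of them and without one in the other: 1 of 3 stereo elements differ; a stereocentre at a saturated ring carbon is drawn S in compound 3 and R in compound 4. The only measured step of the same kind is the one from compound 1 to compound 2, and the limits leave it unreadable, so the numbers shown set neither a direction nor a size for the change to compound 4. With compound 3 sitting at the limit of > 3 mg/kg in this assay, at which 1 of the 3 values shown sits, no step beyond the scatter is expected, a step that the limit leaves unreadable from compound 3 to compound 4, and compound 4 is most likely to return a limit once more. Compound 4 is estimated at 5 mg/kg in this assay, with a range from 2 mg/kg to 15 mg/kg.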

Compound 4, dose for half-maximal effect: 0.024 mg/kg
For compound 4 the middle estimate is 210-fold (2.32 log units) above the measured one; measured number outside the range, below it.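

In this assay the stereocentre at a saturated ring carbon now gives a readable result, an at least 120-fold lower number from compound 3 to compound 4 (2.09 log units; beyond the scatter), with the same atoms and bonds on both sides. The same kind of change from compound 1 to compound 2 cannot be read: the limit of > 1 mg/kg in this assay, at which 2 of the 4 values shown sit. In this pair, the drawn configuration alone separates a limit from a measured number, with one reservation: the fact that one of compounds 3 and 4 is drawn with a defined configuration and the other without, at the place where they differ.

The compounds shown leave open whether configuration at this carbon acts in the same direction on the core of compound 1, where both values remain limits. Also open, from the compounds shown here alone, is how a benzyl group or a fluorophenyl group in place of the phenyl would read with this carbon drawn R.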